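Aryl and alkynyl substituents on the shared core: compound 4

The source may report more compounds than this note shows. Statements on the series, on what has been measured and on what is new or still open speak of the compounds shown alone.

Compound 1 `CCCCC#Cc1cc([C@@H]2O[C@H](CO)[C@@H](O)[C@H]2O)n2ncnc(N)c12`, with hex-1-yn-1-yl on the core, gives 1000 nM in a functional assay on CAPAN-1 cells (Homo sapiens) for antiproliferative activity, with a stated time of 72 h; a higher number here means a weaker inhibitor, a lower number a stronger inhibitor. Compound 2 `Nc1ncnn2c([C@@H]3O[C@H](CO)[C@@H](O)[C@H]3O)cc(C#Cc3cccs3)c12` gives 32000 nM, a step of a 32-fold higher number from compound 1 to compound 2 (1.51 log units; beyond the scatter). Compound 3 `Nc1ncnn2c([C@@H]3O[C@H](CO)[C@@H](O)[C@H]3O)cc(-c3ccccc3F)c12`, carrying 2-fluorophenyl, reports only a limit in this assay, > 100000 nM. That limit is the limit of > 100000 nM in this assay, at which 1 of the 3 values shown sits, so compound 3 stands at the weak end of the numbers shown, with steps of an at least 100-fold higher number from compound 1 to compound 3 (2.00 log units; beyond the scatter) and an at least 3.1-fold higher number from compound 2 to compound 3 (0.49 log units; beyond the scatter), both beyond the scatter, and no exact value.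

Compound 4 `Nc1ncnn2c([C@@H]3O[C@H](CO)[C@@H](O)[C@H]3O)cc(-c3ccc(F)cc3F)c12` differs from compound 3 by fluoro in place of hydrogen on an aromatic carbon, that is 2-fluorophenyl to 2,4-difluorophenyl. Within the data shown here, none of the measured steps concerns a single added fluoro; each exchanges the whole substituent, and those exchanges were large. Nothing among the three compounds suggests that one more fluoro on the aryl ring would move the number by more than the scatter, so the step from compound 3 to compound 4 is expected to be a step that the limit leaves unreadable from compound 3 to compound 4, most likely again ending in a limit. Compound 4 is therefore estimated at 150000 nM, within 50000 nM to 500000 nM.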

Compound 4, half-maximal inhibitory concentration: 50900 nM
Compound 4: middle estimate off by 2.9-fold (0.47 log units), on the high side; low and high end bracket the measured number.
By their numbers in this assay, from the lowest: compound 1; then compounds 2 and 4 (each within the scatter of the next). At a limit, above all of these: compound 3.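

Among these compounds, compound 4 gives the first exact number for an aryl group at this place on the shared core in this assay, and the exchange of hex-1-yn-1-yl for 2,4-difluorophenyl remains a large loss (a 51-fold higher number from compound 1 to compound 4 (1.71 log units; beyond the scatter)). Against the other alkyne, the 2,4-difluorophenyl group cannot be told apart from 2-(thiophen-2-yl)ethynyl (a 1.6-fold higher number from compound 2 to compound 4 (0.20 log units; within the scatter)), so an aryl group at this place need not lie beyond the scatter of that alkyne. The added fluoro, para to a large group and meta to a fluoro group, gives only a floor (an at least 1.9-fold lower number from compound 3 to compound 4 (0.29 log units; that floor lies within the scatter)), and the number for compound 3 is a limit: the limit of > 100000 nM in this assay, at which 1 of the 4 values shown sits.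

From the compounds shown here alone, the true size of the fluoro step stays open. So does whether chloro or methoxy at the same place on the aryl ring, or an amine at the end of the alkyne chain, would change the number.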